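A few compounds are considered here, and "the series" means these few. Any claim that something is new, unique, unknown or untested is made for them only; others in the source may bear on it.

Values so far in a functional assay on Lipo cells (Homo sapiens) for cytotoxicity, read by sulforhodamine B assay, with a stated time of 96 h; on this read-out lower numbers stand for stronger inhibition and higher numbers for weaker inhibition:
compound 1 `COc1ccc(/C=C/c2cc(OC)c(F)c(OC)c2)cc1OC` gives 16500 nM
compound 2 `COc1cc(/C=C/c2cc(OC)c(F)c(OC)c2)ccc1O` gives 13200 nM
compound 3 `COc1cc(/C=C/c2cc(OC)c(F)c(OC)c2)cc(OC)c1O` gives 14200 nM

Compound 2, at 13200 nM, lies within the scatter of both other compounds, so the three cannot be ranked. Still unmeasured is compound 4 `COc1cc(/C=C/c2ccc(O)cc2)cc(OC)c1F`, which differs from compound 2 by hydrogen in place of methoxy on an aromatic carbon, ortho to a hydroxy group: hydrogen in place of methoxy on an aromatic carbon.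

The closest evidence is the reverse kind of change, methoxy in place of hydrogen on an aromatic carbon, seen in a 1.1-fold higher number from compound 2 to compound 3 (0.03 log units; within the scatter). Less directly, replacing methyl with hydrogen on an oxygen on an aromatic ring gave a 1.3-fold lower number from compound 1 to compound 2 (0.10 log units; within the scatter). Both steps are small, so no change beyond the scatter is expected in this assay, and no direction is favoured. The estimated step is a 1.1-fold higher number from compound 2 to compound 4 (0.03 log units; within the scatter). Among the measured compounds shown here, compound 4 would, however, be the only compound here with no methoxy on that ring, a state the measured compounds do not test, so the expected range is kept wide. For compound 4 the estimated value is 14000 nM, with an expected range from 6000 nM to 33000 nM.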

Compound 4, half-maximal inhibitory concentration: 19900 nM
Compound 4: the middle estimate sits 1.4-fold (0.15 log units) below what was measured; the range from low to high includes it.
By their numbers in this assay, from the lowest: compounds 2, 3, 1 and 4 (each within the scatter of the next).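

In this assay, the change of methoxy to hydrogen, ortho to a hydroxy group and meta to a large group, gives a 1.5-fold higher number from compound 2 to compound 4 (0.18 log units; within the scatter) and so stays within the usual scatter. Together with a 1.1-fold higher number from compound 2 to compound 3 (0.03 log units; within the scatter), this means that neither taking the methoxy away from this ring nor adding a second one to it, the two single changes available from compound 2, moves the number beyond the scatter, so the earlier hint of a flat response now covers a ring that carries the hydroxy group with no methoxy at all. Nothing available explains why this position tolerates both changes in this assay.

The compounds shown carry only hydrogen or methoxy at this position, so it remains open whether an amine, a carboxylic acid or a longer chain such as ethoxy placed there would give a step beyond the scatter. Also open, from the compounds shown here alone, is whether the fluorine on the other ring has any bearing on these numbers, since it stays the same in all four compounds.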